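Trimming an isopropyl to methyl on a fused imidazole core

A few compounds are considered here, and "the series" means these few. Any claim that something is new, unique, unknown or untested is made for them only; others in the source may bear on it.

Compound 1 `CCc1nc(C(C)C)c2n1CCN([C@@H](C(=O)NC)c1ccccc1)C2CCc1ccc(C(F)(F)F)cc1` gives 2900 nM in a functional assay on CHO cells for antagonist activity at Orexin receptor type 2 (Homo sapiens), read by FLIPR and calcium flux; a lower number here means a stronger inhibitor, a higher number a weaker inhibitor. Compound 2 `CCc1nc(C)c2n1CCN([C@@H](C(=O)NC)c1ccccc1)C2CCc1ccc(C(F)(F)F)cc1` differs by methyl in place of isopropyl on an aromatic carbon and gives 24 nM, a step of a 120-fold lower number from compound 1 to compound 2 (2.08 log units; beyond the scatter). Compound 3 `CNC(=O)[C@@H](c1ccccc1)N1CCn2c(C(C)C)nc(Cl)c2[C@@H]1CCc1ccc(C(F)(F)F)cc1` carries a different core; how it differs from compound 1 is not broken down here. In this assay compound 3 gives 11 nM. Compound 4 `CNC(=O)[C@@H](c1ccccc1)N1CCn2c(C)nc(Cl)c2[C@@H]1CCc1ccc(C(F)(F)F)cc1` differs from compound 3 by methyl in place of isopropyl on an aromatic carbon. This is the same kind of change as from compound 1 to compound 2, yet not the same: here the carbon sits between two ring nitrogen atoms and two ring bonds from the ring atom that bears a chloro group, whereas before it sat next to the ring nitrogen and two ring bonds from the ring atom that bears an ethyl group. Since compound 3 already gives 11 nM, a smaller gain is expected, a 2.8-fold lower number from compound 3 to compound 4 (0.44 log units; beyond the scatter). Compound 4 is estimated at 4 nM, between 1.2 nM and 14 nM.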

Compound 4, half-maximal inhibitory concentration: 13 nM
Compound 4: middle estimate off by 3.3-fold (0.51 log units), on the low side; low and high end bracket the measured number.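

On the core of compound 3, methyl in place of isopropyl gives a 1.2-fold higher number from compound 3 to compound 4 (0.07 log units; within the scatter) in this assay, so the large gain seen on the core of compound 1 does not recur here. Set side by side, the two steps do not agree: the same change on two cores in this assay, a 120-fold lower number (2.08 log units; beyond the scatter) from compound 1 to compound 2 and a 1.2-fold higher number (0.07 log units; within the scatter) from compound 3 to compound 4, 140-fold (2.15 log units) apart, beyond the scatter of two such steps. This shows that the step cannot be carried unchanged from one of these cores to the other, but two pairs do not show which feature of the cores sets its size, nor how it would run on any further core.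

The compounds shown leave open how an ethyl or a cyclopropyl group on this carbon would read in this assay. They also leave open what a bromo group or a nitrile in place of the chloro group would give.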